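The source may report more compounds than this note shows. Statements on the series, on what has been measured and on what is new or still open speak of the compounds shown alone.

Measured in a functional assay (aorta) with Oryctolagus cuniculus as the target; a higher number here means weaker binding, a lower number tighter binding:
- Compound 1 `CCc1ccc(OCCCN2CCC(C(c3ccc(F)cc3)c3ccc(F)cc3)CC2)c(OC)c1`: 2.51 nM
- Compound 2 `COC(=O)c1ccc(OCCCN2CCC(C(c3ccc(F)cc3)c3ccc(F)cc3)CC2)c(OC)c1`: 1.26 nM
- Compound 3 `COc1cc(C(=O)O)ccc1OCCCN1CCC(C(c2ccc(F)cc2)c2ccc(F)cc2)CC1`: 79.4 nM

Compound 3, the only one of the three with a carboxy group, has the highest number, so it binds most weakly. Compound 4 `COc1cc(OCCCN2CCC(C(c3ccc(F)cc3)c3ccc(F)cc3)CC2)ccc1C(C)=O` has not been measured. It differs from compound 3 as follows: 4-acetyl-3-methoxyphenyl in place of 4-carboxy-2-methoxyphenyl on an oxygen on a saturated carbon. In short, 4-acetyl-3-methoxyphenyl replaces 4-carboxy-2-methoxyphenyl on an oxygen on a saturated carbon, which removes the carboxy.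

Among the compounds with values here, two measured steps bear on this, both large: a 32-fold higher number from compound 1 to compound 3 (1.50 log units; beyond the scatter), and a 63-fold higher number from compound 2 to compound 3 (1.80 log units; beyond the scatter). The two compounds without carboxy stay close, with a 2.0-fold lower number from compound 1 to compound 2 (0.30 log units; within the scatter). Within the data shown here, no measured compound carries the acetyl group, so the expectation is uncertain. The expected change in this assay is large and downward: a 13-fold lower number from compound 3 to compound 4 (1.12 log units; beyond the scatter). The estimate for compound 4 is 6 nM, with an expected range of 1.5 nM to 25 nM.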

Compound 4, dissociation constant: 3.16 nM
Beside the measured number, compound 4's estimate is 1.9-fold (0.28 log units) above it; measured number inside the range.
By their numbers in this assay, from the lowest: compounds 2, 1 and 4 (each within the scatter of the next, the first and the last beyond it); then compound 3.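

In this assay, the acetyl group leaves a much lower number than the carboxy (a 25-fold lower number from compound 3 to compound 4 (1.40 log units; beyond the scatter)) and stays within the scatter of the ethyl group (a 1.3-fold higher number from compound 1 to compound 4 (0.10 log units; within the scatter)), so a third group without the carboxy also gives a low number. A modest gap from the methoxycarbonyl group (a 2.5-fold higher number from compound 2 to compound 4 (0.40 log units; beyond the scatter)) shows that groups without the carboxy are not all equal here. The group names also read 3-methoxy against 2-methoxy, so each step changes two things at once.

Going by these compounds, an amine or a primary amide in this place remains open, as does the acetyl group with the 2-methoxy arrangement. Nothing measured here gives a reason for these steps.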